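Dropping a Methyl: From Compound 2 to Compound 3

The source may hold more compounds than are shown below. What is called first, only, known or untested is meant among the compounds shown, and "the series" means these compounds.

Of the compounds shown here, two have been measured in a functional assay on cells (Cancer cell lines, Homo sapiens) for cytotoxicity, with a stated time of 48 h; on this read-out higher numbers stand for weaker inhibition of growth and lower numbers for stronger inhibition of growth. Compound 1 `COc1c(/C=C2/C(=O)Nc3ccc(Cl)cc32)c2ccccc2n1-c1ccccc1` gives 9330 nM. Compound 2 `COc1cc2c(cc1C)NC(=O)/C2=C/c1c(Cl)n(Cc2cc(OC)c(OC)c(OC)c2)c2cc(C)c(OC)cc12` gives 5500 nM, the lower of the two numbers, yet the gap to compound 1 lies within the scatter, so the two cannot be ranked. Compound 3 `COc1ccc2c(c1)/C(=C\c1c(Cl)n(Cc3cc(OC)c(OC)c(OC)c3)c3cc(C)c(OC)cc13)C(=O)N2` is not yet measured. It differs from compound 2 in one place: hydrogen in place of methyl on an aromatic carbon. For the measured compounds named here, no step between measured compounds bears on such a change, and the expectation is a shift in this assay of no more than the scatter, in no particular direction. Compound 3 is therefore estimated at 6000 nM, within a range from 2500 nM to 14000 nM. The expected step is a 1.1-fold higher number from compound 2 to compound 3 (0.04 log units; within the scatter), essentially none.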

Compound 3, concentration for 50% growth inhibition: 14500 nM
Compound 3: middle estimate off by 2.4-fold (0.38 log units), on the low side, and the stated range ends below it.
By their numbers in this assay, from the lowest: compounds 2, 1 and 3 (each within the scatter of the next, the first and the last beyond it).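

In this assay, hydrogen in place of methyl on this aromatic carbon, ortho to a methoxy group, gives a 2.6-fold higher number from compound 2 to compound 3 (0.42 log units; beyond the scatter). For the compounds shown here, this is the first single-place comparison here, and it shows that the methyl on this carbon is not neutral: losing it weakens growth inhibition by more than the scatter. Nothing at hand explains the shift. From the compounds shown here alone, whether an ethyl group or a fluorine atom on this carbon would match the methyl remains open. So does whether the same change would have a similar effect on a different core.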